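Swapping Methoxy for Chloro on the Phenyl Ring

The source may hold more compounds than are shown below. What is called first, only, known or untested is meant among the compounds shown, and "the series" means these compounds.

Compound 1 `OC(CCn1nc2c(Br)c(Br)c(Br)c(Br)c2n1)c1cccc(Br)c1`: 123%
Compound 2 `COc1cccc(C(O)CCn2nc3c(Br)c(Br)c(Br)c(Br)c3n2)c1`: 106%

In a functional assay on CCRF-CEM cells (Homo sapiens) for antiproliferative activity, read by MTT assay, with a stated time of 24 h, tested at 25 uM (a lower number here means a stronger effect, a higher number a weaker effect of the compound at the concentration tested), compound 1 gives 123% and compound 2 gives 106%, so compound 2 stands lowest of the two numbers. The unmeasured compound 3 `OC(CCn1nc2c(Br)c(Br)c(Br)c(Br)c2n1)c1cccc(Cl)c1` differs from compound 2 by chloro in place of methoxy on an aromatic carbon. Among the measured compounds shown here, only one measured step bears on this: a number 17 percentage points lower from compound 1 to compound 2 (beyond the scatter), a modest drop beyond the scatter. Compound 3 is expected to sit higher than compound 2 because a number 17 percentage points lower from compound 1 to compound 2 (beyond the scatter) ran downward when a halogen gave way to methoxy. Compound 3 is therefore estimated at 117%, within 100% to 134%. The expected step is a number 11 percentage points higher from compound 2 to compound 3 (beyond the scatter).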

Compound 3, a percentage reported as activity, at one concentration (the size of the read-out at that concentration, not a potency): 118%
The estimate for compound 3 lay 1 percentage points below the measured number, and the stated range covers the measured number.
By their numbers in this assay, from the lowest: compound 2; then compounds 3 and 1 (each within the scatter of the next).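

At this position, methoxy now stands apart from both halogens in this assay: putting chloro in its place gives a number 12 percentage points higher from compound 2 to compound 3 (beyond the scatter) and so reverses the earlier drop. Chloro in place of bromo gives a number 5 percentage points lower from compound 1 to compound 3 (within the scatter), so this assay does not separate these two halogens. No measurement here explains why methoxy differs from them. From the compounds shown here alone, it remains open how an amine, a carboxylic acid or a longer ether chain on this aromatic carbon would compare, and whether the methoxy result would hold at other concentrations.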